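The source may hold more compounds than are shown below. What is called first, only, known or untested is meant among the compounds shown, and "the series" means these compounds.

In an ADME assay on microsomes from liver (Rattus norvegicus) for metabolic stability, with a stated time of 10 min (a lower number here means that less of the compound is left, a higher number that more of the compound is left), compound 1 (`COc1ccccc1-n1nc(C2CC(C)(C)OC(C)(C)C2)cc1-c1ccc(Cl)cc1`) gives 96% and stands highest of the two measured compounds, while compound 2 (`COc1ccccc1-n1nc([C@@H]2CCO[C@@H](C(C)C)C2)cc1-c1ccc(Cl)cc1`) gives 14% and lies far lower. Compound 3 (`COc1ccccc1-n1nc([C@@H]2CCO[C@H](C(C)C)C2)cc1-c1ccc(Cl)cc1`) has not yet been measured. The change from compound 1 to compound 3 (2-isopropyloxan-4-yl in place of 2,2,6,6-tetramethyloxan-4-yl on an aromatic carbon) puts 2-isopropyloxan-4-yl in place of 2,2,6,6-tetramethyloxan-4-yl on an aromatic carbon of the shared core. For the measured compounds named here, the one measured step that makes the same exchange of groups is large (a number 82 percentage points lower from compound 1 to compound 2 (beyond the scatter)), so a large fall is also expected for compound 3 in this assay as well. That single step cannot show how much the arrangement of the entering group in space matters, so the expected range stays wide. The estimated step is large (a number 76 percentage points lower from compound 1 to compound 3 (beyond the scatter)). For compound 3 the expected value is 20% (estimated range 5% to 55%).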

Compound 3, percent of the compound remaining: 21%
Compound 3: middle estimate off by 1 percentage points, on the low side; the range from low to high includes it.
By their numbers in this assay, from the lowest: compounds 2 and 3 (each within the scatter of the next); then compound 1.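

The low number of compound 2 is not a one-off in this assay, since the other drawn form of the entering group gives a second large fall (a number 75 percentage points lower from compound 1 to compound 3 (beyond the scatter)). Inverting one stereocentre at a saturated ring carbon leaves no readable difference (a number 7 percentage points higher from compound 2 to compound 3 (within the scatter)). In these two forms, then, the low number goes with the 2-isopropyloxan-4-yl group whichever way this centre is drawn, and the comparison is a clean one: the fact that compounds 2 and 3 differ only in the configuration as drawn.

The compounds shown leave open the two forms in which the other stereocentre is inverted, and whether the high number of compound 1 needs all four methyl groups. A 2,2-dimethyloxan-4-yl group or a plain oxan-4-yl group at this position would begin to answer the second question.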